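Azole exchange on the sulfur-linked chain: notes on compound 3

This account rests on a few compounds, and the source may have more. Where it says the series, first, only, none or still open, it means among the compounds named here.

Measured so far:
- compound 1 `N#Cc1c(N)nc(SCC(=O)NCO)c(C#N)c1-c1ccc(OCC2CC2)cc1`: 182 nM
- compound 2 `N#Cc1c(N)nc(SCc2ncc[nH]2)c(C#N)c1-c1ccc(OCC2CC2)cc1`: 9.5 nM

In a functional assay on CHO cells for agonist activity at adenosine receptor A2b (Homo sapiens), read by AlphaScreen and cAMP accumulation (a higher number here means that more compound is needed for the effect, a lower number that less compound is needed), compound 1 gives 182 nM and compound 2 gives 9.5 nM. Of the two numbers compound 2 stands lowest; its nearest neighbour is compound 1, and the step of a 19-fold lower number from compound 1 to compound 2 (1.28 log units; beyond the scatter) separates them. Compound 3 `N#Cc1c(N)nc(SCc2ncn[nH]2)c(C#N)c1-c1ccc(OCC2CC2)cc1` has not been measured. It differs from compound 2 in one place: 1H-1,2,4-triazol-5-yl in place of 1H-imidazol-2-yl on a saturated chain carbon bound to a sulfur. Going by the values given here, no measured step exchanges one azole for another. Among the compounds with values here, the only step available, a 19-fold lower number from compound 1 to compound 2 (1.28 log units; beyond the scatter), replaces an open-chain amide end with the imidazole ring and is large, so it shows that what sits on the chain carbon bound to sulfur moves the number strongly, but it does not tell how the two azoles compare. Because compound 2 gives 9.5 nM with an azole already on that carbon and the change keeps a five-membered aromatic ring there, the expected step of a 1.6-fold higher number from compound 2 to compound 3 (0.20 log units; within the scatter) is small, possibly within the scatter, in either direction. Compound 3 is expected to give about 15 nM in this assay, with a range from 4 nM to 60 nM.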

Compound 3, half-maximal effective concentration: 51 nM
Compound 3: middle estimate off by 3.4-fold (0.53 log units), on the low side, within the range that was stated.
By their numbers in this assay, from the lowest: compound 2; then compound 3; then compound 1.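

In this assay, the identity of the azole on a saturated chain carbon bound to a sulfur matters: exchanging 1H-imidazol-2-yl for 1H-1,2,4-triazol-5-yl gives a 5.4-fold higher number from compound 2 to compound 3 (0.73 log units; beyond the scatter) even though the ring size, aromaticity and hydrogen-bond donor count stay the same, while one ring nitrogen and one hydrogen-bond acceptor are added. A five-membered aromatic ring at this position therefore does not by itself secure the low number of compound 2 at 9.5 nM. The triazole still improves on the open-chain amide end, with a 3.6-fold lower number from compound 1 to compound 3 (0.55 log units; beyond the scatter), so part of the gain survives the exchange, though less of it than in a 19-fold lower number from compound 1 to compound 2 (1.28 log units; beyond the scatter).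

Still open, on these data alone, is how a pyrazole, a tetrazole, a primary amine or a carboxylic acid would behave on this carbon, and whether a longer chain between the sulfur and the azole would change the order of the two rings. The data shown include no evidence that explains the difference between the two azoles.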